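The source may report more compounds than this note shows. Statements on the series, on what has been measured and on what is new or still open speak of the compounds shown alone.

Compound 1 `Cc1ccc(Nc2cc(Oc3c(C)cc(Br)cc3C)c([N+](=O)[O-])cc2[N+](=O)[O-])cc1` gives 53000 nM in an ADME assay on H9 cells (Homo sapiens) for cytotoxicity, read by XTT assay, with a stated time of 6 days; a higher number here means that more compound is tolerated, a lower number that less compound is tolerated. Compound 2 `COc1ccc(Nc2cc(Oc3c(C)cccc3C)c([N+](=O)[O-])cc2[N+](=O)[O-])cc1` gives > 61100 nM in this assay, a limit rather than a number. Compound 3 `COc1ccc(Nc2cc(Oc3c(C)cc(Br)cc3C)c([N+](=O)[O-])cc2[N+](=O)[O-])cc1` gives 51200 nM in this assay.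

Compound 3 and compound 1 sit within the scatter of each other, as a 1.0-fold lower number from compound 1 to compound 3 (0.02 log units; within the scatter) shows, while compound 2 only sets a limit, (the limit of > 61100 nM in this assay, at which 1 of the 3 values shown sits). Compound 4 `Cc1cc(Br)cc(C)c1Oc1cc(Nc2ccc([N+](=O)[O-])cc2)c([N+](=O)[O-])cc1[N+](=O)[O-]` differs from compound 3 in one place: nitro in place of methoxy on an aromatic carbon. Neither measured step covers this change. Both, a 1.0-fold lower number from compound 1 to compound 3 (0.02 log units; within the scatter) and an at least 1.1-fold lower number from compound 2 to compound 3 (0.07 log units; that floor lies within the scatter), stayed within the scatter, so in this assay the step from compound 3 to compound 4 is expected to stay within it as well, a 1.0-fold lower number from compound 3 to compound 4 (0.01 log units; within the scatter). Compound 4 is therefore estimated at 50000 nM, between 25000 nM and 100000 nM.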

Compound 4, half-maximal cytotoxic concentration: > 49700 nM
Compound 4 ended at the assay's limit; the forecaster's own chance of this, stated with the estimate: 30%; the middle value is on the limit's open side.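

Compound 4 gives only a limit, > 49700 nM, so its steps from compound 3 and from compound 1 cannot be read. The compounds shown leave open whether nitro in place of methoxy changes the number in this assay at all.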